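The source may report more compounds than this note shows. Statements on the series, on what has been measured and on what is new or still open speak of the compounds shown alone.

Among the measured compounds shown here, compound 1 `CC(Nc1ccccc1Oc1ccc(Cl)cc1)=C1C(=O)CC(c2ccccc2)CC1=O` is the weakest of the three compounds measured so far in a functional assay on HMEC-1 cells (Homo sapiens) for antiproliferative activity, read by cell counting, with a stated time of 4 days; a higher number here means a weaker inhibitor, a lower number a stronger inhibitor: in it compound 1 gives 260 nM, the highest of the three numbers. Compound 2 `CC(Nc1ccccc1Oc1ccccc1)=C1C(=O)CC(c2ccccc2)CC1=O` gives 160 nM in this assay, and compound 3 `COc1cc(Oc2ccccc2NC(C)=C2C(=O)CC(c3ccccc3)CC2=O)ccc1N` gives 29 nM. The step of a 1.6-fold lower number from compound 1 to compound 2 (0.21 log units; within the scatter) stays within the scatter, whereas the steps of a 9.0-fold lower number from compound 1 to compound 3 (0.95 log units; beyond the scatter) and a 5.5-fold lower number from compound 2 to compound 3 (0.74 log units; beyond the scatter) go beyond it.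

Compound 4 `CC(Nc1ccccc1Oc1cccc(F)c1)=C1C(=O)CC(c2ccccc2)CC1=O` differs from compound 1 in one place: 3-fluorophenyl in place of 4-chlorophenyl on an oxygen on an aromatic ring. The measured step that bears most directly on this change is a 1.6-fold lower number from compound 1 to compound 2 (0.21 log units; within the scatter), since there too a halogen is replaced on the aromatic ring that sits on the oxygen, and the number moved only within the scatter. The larger steps to compound 3 involve a 4-amino-3-methoxyphenyl group, which is not the group entering here, so they offer little guidance. On this basis only a small step is expected in this assay, perhaps a slightly lower number, but not beyond the scatter. The expected step is a 1.3-fold lower number from compound 1 to compound 4 (0.11 log units; within the scatter). Compound 4 is therefore estimated to give 200 nM in this assay, within a range from 90 nM to 450 nM.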

Compound 4, half-maximal inhibitory concentration: 360 nM
Beside the measured number, compound 4's estimate is 1.8-fold (0.26 log units) below it; low and high end bracket the measured number.
By their numbers in this assay, from the lowest: compound 3; then compounds 2, 1 and 4 (each within the scatter of the next, the first and the last beyond it).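

Among the compounds shown here, replacing 4-chlorophenyl with 3-fluorophenyl on this oxygen gives a 1.4-fold higher number from compound 1 to compound 4 (0.14 log units; within the scatter) in this assay, so this halogen exchange does not separate the two compounds, yet the fluoro group on the unsubstituted phenyl gives a 2.3-fold higher number from compound 2 to compound 4 (0.35 log units; beyond the scatter) and is the first halogen change at this place to pass the scatter, as the chloro pair gave only a 1.6-fold lower number from compound 1 to compound 2 (0.21 log units; within the scatter) in the same read-out. Going the other way, a 12-fold higher number from compound 3 to compound 4 (1.09 log units; beyond the scatter) is the largest step among the four compounds and shows that the 4-amino-3-methoxyphenyl group of compound 3 stands well apart from the 3-fluorophenyl group as well as from the groups compared earlier. No supporting measurement is available to explain these differences.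

The compounds shown leave open whether the halogen's identity or its place on the ring matters, which 3-chlorophenyl and 4-fluorophenyl groups would separate. They also leave open whether the amine or the methoxy group of compound 3 accounts for its lower number, which a 4-aminophenyl or a 3-methoxyphenyl group on the same oxygen would address.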